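A few compounds are considered here, and "the series" means these few. Any claim that something is new, unique, unknown or untested is made for them only; others in the source may bear on it.

The series shares one core, carried by compound 1 `CC1=CC[C@H](C(C)(C)NC(=S)N/N=C/c2ccccc2)CC1`. In a functional assay on K562 cells (Homo sapiens) for inhibition, read by sulforhodamine B assay, with a stated time of 48 h (on this read-out higher numbers stand for weaker inhibition of growth and lower numbers for stronger inhibition of growth), compound 1 gives 47600 nM. Compound 2 `CC1=CC[C@H](C(C)(C)NC(=S)N/N=C/c2ccccc2O)CC1` has a hydroxy in place of hydrogen on an aromatic carbon. In this assay compound 2 returns only the limit > 100000 nM, not a number. Compound 3 `CC1=CC[C@H](C(C)(C)NC(=S)N/N=C/c2cccc(Cl)c2)CC1` has a chloro in place of hydrogen on an aromatic carbon. In this assay compound 3 also stands only at the limit > 100000 nM, so its place on the numbers is known merely as a limit. The step of an at least 2.1-fold higher number from compound 1 to compound 3 (0.32 log units; beyond the scatter) and the parallel step an at least 2.1-fold higher number from compound 1 to compound 2 (0.32 log units; beyond the scatter) are both at least modest, while the step that the two limits leave unreadable from compound 2 to compound 3 cannot be read. Compound 4 `CC1=CC[C@H](C(C)(C)NC(=S)N/N=C/c2cccc([N+](=O)[O-])c2)CC1` differs from compound 3 by nitro in place of chloro on an aromatic carbon. Among the measured compounds shown here, no measured step swaps one substituent for another on that ring, so the bearing steps are only those from compound 1. Given (the limit of > 100000 nM in this assay, at which 2 of the 3 values shown sit), compound 4 is expected to stay near that limit, estimated at 100000 nM with a range from 40000 nM to 250000 nM. The step of a number no higher from compound 3 to compound 4 (the limit leaves the size open) is expected to be no more than modest.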

Compound 4, concentration for total growth inhibition: > 100000 nM
Compound 4 was reported as a limit; the forecaster's own chance of this, stated with the estimate: 60%; the middle value sits exactly at the limit.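

In this assay, nitro on an aromatic carbon, meta to a large group, gives an at least 2.1-fold higher number from compound 1 to compound 4 (0.32 log units; beyond the scatter), so at this place a second substituent, after the chloro of compound 3, also departs from the unsubstituted ring of compound 1. Nitro enters with more heavy atoms and with hydrogen-bond acceptors that chloro lacks, yet compound 4 is again reported only as a limit, and the steps among compound 2, compound 3 and compound 4 cannot be read. Growth inhibition in this series now rests on a single number: the limit of > 100000 nM in this assay, at which 3 of the 4 values shown sit.

On these data alone, it remains open how compound 2, compound 3 and compound 4 rank among themselves. As far as these compounds go, it is also open whether an amine or a carboxylic acid at this place would give a number at all, or one lower than that of compound 1.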